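The compounds below may be only part of what the source reports. "The series", "measured", "known", "first", "only" and "open" are said of these compounds alone.

Of the compounds shown here, three built on a shared core have been measured in an assay on membranes from CHO-K1 cells for displacement of a labelled ligand from 5-hydroxytryptamine receptor 7 (Homo sapiens), read by scintillation counting; a lower number here means a stronger inhibitor, a higher number a weaker inhibitor. Compound 1 `COc1cc2ncnc(N3CCC(CN4CCN(c5ccccc5O)CC4)C3)c2cc1OC` gives 661 nM. Compound 2 `COc1cc2ncnc(N3CCC(CN4CCN(c5ccccc5OC)CC4)C3)c2cc1OC` gives 56.2 nM, and compound 3 `COc1cc2ncnc(N3CCC(CN4CCN(c5cccc(Cl)c5Cl)CC4)C3)c2cc1OC` gives 347 nM. Compound 3 stands second highest of the three numbers: against compound 1 it shows a 1.9-fold lower number from compound 1 to compound 3 (0.28 log units; within the scatter), and against compound 2 it shows a 6.2-fold higher number from compound 2 to compound 3 (0.79 log units; beyond the scatter). Among the measured compounds shown here, the one step not involving compound 3, a 12-fold lower number from compound 1 to compound 2 (1.07 log units; beyond the scatter), shows how much the group on the amine nitrogen of the six-membered non-aromatic ring with 2 nitrogen can move this assay.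

Compound 4 `COc1cc2ncnc(N3CCC(CN4CCN(c5ccccn5)CC4)C3)c2cc1OC` has not yet been measured. It differs from compound 3 in one place: pyridin-2-yl in place of 2,3-dichlorophenyl on an amine nitrogen in a ring. For the measured compounds named here, the steps that bear on this change are those which swap the aryl group on that ring nitrogen, namely a 6.2-fold higher number from compound 2 to compound 3 (0.79 log units; beyond the scatter) and a 1.9-fold lower number from compound 1 to compound 3 (0.28 log units; within the scatter); the first is modest, the second within the scatter. Pyridin-2-yl carries an acceptor like 2-methoxyphenyl but no substituent, so compound 4 is expected to land somewhere between the numbers of compound 2 and compound 1, with a step from compound 3 that is estimated to be a 1.2-fold lower number from compound 3 to compound 4 (0.06 log units; within the scatter). Compound 4 is therefore expected to give about 300 nM in this assay, within a range from 80 nM to 1100 nM.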

Compound 4, inhibition constant: 282 nM
The estimate for compound 4 lay 1.1-fold (0.03 log units) above the measured number, within the range that was stated.
By their numbers in this assay, from the lowest: compound 2; then compounds 4, 3 and 1 (each within the scatter of the next, the first and the last beyond it).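

Placing pyridin-2-yl on the amine nitrogen in the ring instead of 2,3-dichlorophenyl leaves the reading in this assay essentially unchanged (a 1.2-fold lower number from compound 3 to compound 4 (0.09 log units; within the scatter)), so two aryl groups that differ in heavy atoms, ring hetero atom and hydrogen-bond acceptor count cannot be told apart at this position. Pyridin-2-yl does not match 2-methoxyphenyl (a 5.0-fold higher number from compound 2 to compound 4 (0.70 log units; beyond the scatter)) and separates modestly from 2-hydroxyphenyl (a 2.3-fold lower number from compound 1 to compound 4 (0.37 log units; beyond the scatter)), which leaves compound 2 as the strongest inhibitor of the four, with each of its steps to the others beyond the scatter. Nothing shown here explains these differences.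

As far as these compounds go, what remains open is whether the methoxy group itself accounts for the lower number of compound 2, a question that a plain phenyl, a 2-ethoxyphenyl or a 3-methoxypyridin-2-yl on the same nitrogen would bear on directly. From the compounds shown here alone, it is also open whether a single chlorine on the phenyl ring would read like 2,3-dichlorophenyl, and whether the order of these aryl groups would hold on a core other than the shared one.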